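Swapping ethyl for cyclopropyl on a clearance-heavy compound

The source may hold more compounds than are shown below. What is called first, only, known or untested is meant among the compounds shown, and "the series" means these compounds.

Compound 1 `CCn1nc(CC(=O)Nc2ccc(OC(F)(F)F)c(Cl)c2)c2ccccc2c1=O`: 81.7 mL/min/kg
Compound 2 `O=C(O)C1(c2nn(Cc3cn4cc(OCC5CC5)c(Cl)cc4n3)c3ccccc3c2=O)CC1`: < 53.4 mL/min/kg (a limit of the assay)

For the measured compounds named here, in an ADME assay on microsomes from liver (Mus musculus) for metabolic stability (on this read-out lower numbers stand for slow clearance and higher numbers for fast clearance), compound 1 gives 81.7 mL/min/kg, the only exact number so far. Compound 2 returns a limit of the assay rather than a number, < 53.4 mL/min/kg. With one exact value and one limit, there is no series against which to rank compound 1.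

The next compound to be tested is compound 3 `O=C(Cc1nn(C2CC2)c(=O)c2ccccc12)Nc1ccc(OC(F)(F)F)c(Cl)c1`. It keeps the core of compound 1 and carries cyclopropyl in place of ethyl on an aromatic nitrogen. Going by the values given here, no measured pair of compounds shows this swap, so its effect in this assay cannot be read from the data. The expectation therefore starts from compound 1 at 81.7 mL/min/kg, and no change beyond the usual scatter of the assay is expected. The estimated step is small: a 1.1-fold lower number from compound 1 to compound 3 (0.04 log units; within the scatter). For compound 3 the estimated clearance is 75 mL/min/kg, with an expected range from 42 mL/min/kg to 130 mL/min/kg.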

Compound 3, clearance: 2300 mL/min/kg
For compound 3 the middle estimate is 31-fold (1.49 log units) below the measured one; measured number outside the range, above it.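

In this assay, this aromatic nitrogen proves to be a highly sensitive position: with the rest of the structure left unchanged, cyclopropyl in place of ethyl gives a 28-fold higher number from compound 1 to compound 3 (1.45 log units; beyond the scatter). For the compounds shown here, this is the first measured pair that differs in one place, so it gives the first direct reading of what a change at this nitrogen can do, and the step is large even though both groups are small, contain only carbon and carry no net charge. Nothing in the data shown accounts for a step of this size.

A single pair cannot tell whether the sharp rise is specific to cyclopropyl or would follow other departures from ethyl at this nitrogen, and a longer chain such as propyl or a larger ring such as cyclobutyl would help separate those two readings. From the compounds shown here alone, it also remains open whether the same swap would produce a comparable step in a compound carrying an amine in place of the amide, since one pair on one core cannot establish a general rule.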